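This account rests on a few compounds, and the source may have more. Where it says the series, first, only, none or still open, it means among the compounds named here.

Working notes on the series.

For the measured compounds named here, compound 3 `Clc1ccc(NCc2cn(-c3ccccc3)nc2-c2ccccc2)cc1` stands at the lowest of the three numbers so far in an ADME assay on Vero 76 cells (Chlorocebus sabaeus) for cytotoxicity, read by MTT assay, with a stated time of 96 h (on this read-out higher numbers stand for lower toxicity in this test and lower numbers for higher toxicity in this test), with 65000 nM; compound 2 `Brc1ccc(NCc2cn(-c3ccccc3)nc2-c2ccc(Br)cc2)cc1` gives 88000 nM and compound 1 `Cc1ccc(-c2nn(-c3ccccc3)cc2CNc2ccc(Br)cc2)cc1` gives 92000 nM, and both gaps to compound 3 lie within the scatter, so the three are not separable on this read-out. Compound 4 `Brc1ccc(NCc2cn(-c3ccccc3)nc2-c2ccccc2)cc1` differs from compound 3 by bromo in place of chloro on an aromatic carbon. Going by the values given here, the one measured step that bears on a halogen exchange on this ring is a 1.0-fold lower number from compound 1 to compound 2 (0.02 log units; within the scatter), which stayed within the scatter. A similar outcome is expected here: the step of no change at the digits printed from compound 3 to compound 4 (within the scatter) is estimated to be none beyond the scatter. Compound 4 is therefore expected to give 65000 nM, with a range of 35000 nM to 120000 nM in this assay.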

Compound 4, half-maximal cytotoxic concentration: 52000 nM
Compound 4: middle estimate off by 1.3-fold (0.10 log units), on the high side; measured number inside the range.
By their numbers in this assay, from the lowest: compounds 4, 3, 2 and 1 (each within the scatter of the next).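

Bromo and chloro on the aniline ring are not separable here: a 1.3-fold lower number from compound 3 to compound 4 (0.10 log units; within the scatter) in this assay, so this exchange on the (4-chlorophenyl)amino group leaves the read-out within the scatter. Hydrogen in place of bromo gives a 1.7-fold lower number from compound 2 to compound 4 (0.23 log units; within the scatter), and hydrogen in place of methyl gives a 1.8-fold lower number from compound 1 to compound 4 (0.25 log units; within the scatter); both are also within the scatter, so neither substituent is separated from hydrogen. From the compounds shown here alone, whether an amine or a carboxylic acid in place of the halogen would give a step beyond the scatter remains open. Nothing available explains these numbers.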